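Side chain swap from compound 3 to compound 4

The source may hold more compounds than are shown below. What is called first, only, known or untested is meant among the compounds shown, and "the series" means these compounds.

In a functional assay on HepG2 cells (Homo sapiens) for antiproliferative activity, read by MTT assay (a lower number here means a stronger inhibitor, a higher number a weaker inhibitor), compound 1 (`CC1(C)CCc2cc(C(=O)/C=C/c3ccc(OCc4cn(-c5ccc(Br)cc5)nn4)cc3)c(O)cc2O1`) is reported as "not active" (no number reported), with no number. Compound 2 (`Cc1ccc(-n2cc(COc3ccc(/C=C/C(=O)c4cc5c(cc4O)OC(C)(C)CC5)cc3)nn2)cc1Br`) gives 117000 nM, and compound 3 (`CC1(C)CCc2cc(C(=O)/C=C/c3ccc(OCc4cn(Cc5ccc([N+](=O)[O-])cc5)nn4)cc3)c(O)cc2O1`) gives 109000 nM. These two numbers are level within the scatter, so compound 3 stands with compound 2 and not apart from it.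

Compound 4 (`CCCCCn1cc(COc2ccc(/C=C/C(=O)c3cc4c(cc3O)OC(C)(C)CC4)cc2)nn1`) is next, with the change butyl in place of 4-nitrophenyl on a saturated chain carbon bound to an aromatic nitrogen, or, cut one bond further out, 4-nitrobenzyl to pentyl.

Among the compounds with values here, the one measured step that bears on this is a 1.1-fold lower number from compound 2 to compound 3 (0.03 log units; within the scatter), with 4-nitrobenzyl in place of 3-bromo-4-methylphenyl on an aromatic nitrogen. It stays within the scatter. Within the data shown here, no measured compound carries a group without a ring at this place, so the expectation is tentative, and compound 1 shows that a number is not assured.

No step beyond the scatter is expected in this assay. The expected step is a 1.1-fold lower number from compound 3 to compound 4 (0.04 log units; within the scatter). Compound 4 is estimated at 100000 nM, with an expected range of 45000 nM to 220000 nM.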

Compound 4, half-maximal inhibitory concentration: 95800 nM
Estimate against measurement, compound 4: 1.0-fold (0.02 log units) above, within the range that was stated.
By their numbers in this assay, from the lowest: compounds 4, 3 and 2 (each within the scatter of the next).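

In this assay, within the data shown here, the pentyl group is the first entry without a ring at this place, and replacing the 4-nitrobenzyl group with it gives a 1.1-fold lower number from compound 3 to compound 4 (0.06 log units; within the scatter) while replacing the 3-bromo-4-methylphenyl group gives a 1.2-fold lower number from compound 2 to compound 4 (0.09 log units; within the scatter) as the paired reading. A ring on this aromatic nitrogen is therefore not needed for a number at this level, and the nitro group can go as well, at least across compounds 2, 3 and 4. Nothing measured independently of this assay bears on why the three groups read alike.

All three numbers remain level, so no group shown here moves the value beyond the scatter. Going by these compounds, whether a longer chain, or a chain ending in an amine or a carboxylic acid, would do so remains open, as does the standing of compound 1 without a number.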